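Removing a methyl from a methoxy group in two related cores

The source may hold more compounds than are shown below. What is called first, only, known or untested is meant among the compounds shown, and "the series" means these compounds.

In a functional assay on MCF7 cells (Homo sapiens) for antiproliferative activity, read by sulforhodamine B assay, with a stated time of 48 h (on this read-out lower numbers stand for stronger inhibition and higher numbers for weaker inhibition), the measured compounds are:
compound 1, `COc1ccc(/C=C/C(=O)c2ccccc2-c2ccc(F)cc2)cc1OC`, 240 nM
compound 2, `COc1cc(/C=C/C(=O)c2ccccc2-c2ccc(F)cc2)ccc1O`, 4000 nM
compound 3, `COc1ccc(C(=O)/C=C/c2ccccc2-c2ccc(F)cc2)cc1OC`, 7100 nM

Compound 2 differs from compound 1 by hydrogen in place of methyl on an oxygen on an aromatic ring, and this change gave a 17-fold higher number from compound 1 to compound 2 (1.22 log units; beyond the scatter). Compound 3 has the same atoms as compound 1 joined differently; the difference between the two cores is not broken down here. Compound 4, `COc1cc(C(=O)/C=C/c2ccccc2-c2ccc(F)cc2)ccc1O`, has not yet been tested in this assay. It differs from compound 3 by hydrogen in place of methyl on an oxygen on an aromatic ring, the same change at the same kind of place. Since compound 1 lost potency through a 17-fold higher number from compound 1 to compound 2 (1.22 log units; beyond the scatter), a step in the same direction is expected from compound 3, roughly a 5.6-fold higher number from compound 3 to compound 4 (0.75 log units; beyond the scatter), though the size may differ on this other core. For compound 4 the expected value in this assay is 40000 nM, between 10000 nM and 150000 nM.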

Compound 4, half-maximal inhibitory concentration: 5400 nM
Beside the measured number, compound 4's estimate is 7.4-fold (0.87 log units) above it; measured number below the stated range.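

On the core of compound 3, going from methoxy to hydroxy gave a 1.3-fold lower number from compound 3 to compound 4 (0.12 log units; within the scatter) in this assay, so the loss of potency seen on the core of compound 1 did not reappear. The same change therefore did not carry over between these two cores, as the two steps set side by side show: the same change on two cores in this assay, a 17-fold higher number (1.22 log units; beyond the scatter) from compound 1 to compound 2 and a 1.3-fold lower number (0.12 log units; within the scatter) from compound 3 to compound 4, 22-fold (1.34 log units) apart, beyond the scatter of two such steps. This rests on one pair per core, so it shows that a step measured on one core cannot simply be transferred to the other here, but not why the cores differ or how a further core would respond.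

The compounds shown leave open what a longer chain such as ethoxy, or an amine in place of the methoxy group, would do on either core.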